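The compounds below may be only part of what the source reports. "The series", "measured", "known", "first", "only" and "open" are said of these compounds alone.

Measured compounds:
Compound 1 `COc1ccc(-c2sc(N(C)C)nc2-c2cc(OC)c(OC)c(OC)c2)cc1` gives 1890 nM in a functional assay on HL-60 cells (Homo sapiens) for antiproliferative activity, read by MTT assay, with a stated time of 72 h; on this read-out higher numbers stand for weaker inhibition and lower numbers for stronger inhibition.
Compound 2 `CCOc1ccc(-c2sc(N(C)C)nc2-c2cc(OC)c(OC)c(OC)c2)cc1` gives 303 nM in this assay.
Compound 3 `COc1ccc(-c2sc(C)nc2-c2cc(OC)c(OC)c(OC)c2)cc1` gives 3430 nM in this assay.

Compound 4 `CCOc1ccc(-c2sc(C)nc2-c2cc(OC)c(OC)c(OC)c2)cc1` is not yet measured. The change from compound 3 to compound 4 is methyl in place of hydrogen on a saturated chain carbon bound to an oxygen on an aromatic ring. The same change, (methyl in place of hydrogen on a saturated chain carbon bound to an oxygen on an aromatic ring), has one measured precedent in this set, where it gave a 6.2-fold lower number from compound 1 to compound 2 (0.80 log units; beyond the scatter). The place of the change is described in the same words for both pairs. The two cores differ by methyl in place of dimethylamino on an aromatic carbon, a difference that gave a 1.8-fold higher number from compound 1 to compound 3 (0.26 log units; within the scatter), so the two starting points lie close together. Among the measured compounds shown here, on this single precedent a step of roughly the earlier size is expected, a 5.7-fold lower number from compound 3 to compound 4 (0.76 log units; beyond the scatter), resting on a 6.2-fold lower number from compound 1 to compound 2 (0.80 log units; beyond the scatter); with only one precedent the range is kept wide. Compound 4 is expected to give about 600 nM in this assay, between 200 nM and 1800 nM.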

Compound 4, half-maximal inhibitory concentration: 253 nM
For compound 4 the middle estimate is 2.4-fold (0.38 log units) above the measured one; low and high end bracket the measured number.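

In this assay the methoxy to ethoxy change gives a 14-fold lower number from compound 3 to compound 4 (1.13 log units; beyond the scatter) on the methyl core and agrees with the step on the dimethylamino core: the same change on two cores in this assay, a 6.2-fold lower number (0.80 log units; beyond the scatter) from compound 1 to compound 2 and a 14-fold lower number (1.13 log units; beyond the scatter) from compound 3 to compound 4, 2.2-fold (0.34 log units) apart, within the scatter of two such steps
Methyl in place of dimethylamino stays within the scatter on the ethoxy pair, with a 1.2-fold lower number from compound 2 to compound 4 (0.08 log units; within the scatter) in line with the methoxy pair: the same change on two cores in this assay, a 1.8-fold higher number (0.26 log units; within the scatter) from compound 1 to compound 3 and a 1.2-fold lower number (0.08 log units; within the scatter) from compound 2 to compound 4, 2.2-fold (0.34 log units) apart, within the scatter of two such steps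
So the ethoxy step carries between these two cores, but two pairs do not show that it would carry to a core with any other group in that place.

Still open, on these data alone, is whether a longer chain such as propoxy, or a branched one such as isopropoxy, extends the step. Also open, as far as these compounds go, is whether a primary amine or morpholine in place of dimethylamino leaves the number unchanged.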